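A few compounds are considered here, and "the series" means these few. Any claim that something is new, unique, unknown or untested is made for them only; others in the source may bear on it.

Measured compounds:
Compound 1, `COc1cc(-c2nnc(SCc3c(F)cccc3F)o2)ccc1O`, in a functional assay on cells (T-cell, Mus musculus, strain BALB/c) for inhibition, read by MTT assay, with stated times of 24 h and 72 h (a lower number here means a stronger inhibitor, a higher number a weaker inhibitor), gives 10100 nM.
Compound 2, `COc1cc(-c2nnc(SCc3ccc(F)cc3F)o2)ccc1O`, in this assay gives 9690 nM.

For the measured compounds named here, compound 2 has the lowest of the two numbers, but its only neighbour is compound 1, and a 1.0-fold lower number from compound 1 to compound 2 (0.02 log units; within the scatter) lies within the scatter, so the two compounds cannot be told apart on these data. Compound 3, `COc1cc(-c2nnc(SCc3ccccc3Cl)o2)ccc1O`, has not yet been measured in this assay. It differs from compound 2 in one place: 2-chlorophenyl in place of 2,4-difluorophenyl on a saturated chain carbon bound to a sulfur. Going by the values given here, the only measured step that bears on this change is a 1.0-fold lower number from compound 1 to compound 2 (0.02 log units; within the scatter), which altered only the pattern of fluorine on the phenyl ring and produced nothing beyond the scatter. Among the compounds with values here, no measured step exchanges fluorine for chlorine or reduces two halogens to one, so that part of the change has no direct guide in the data. The expectation for compound 3 is therefore a step of about a 1.0-fold lower number from compound 2 to compound 3 (0.01 log units; within the scatter), meaning no change beyond the scatter. Compound 3 is estimated to give 9500 nM, with a range from 4500 nM to 20000 nM.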

Compound 3, half-maximal inhibitory concentration: 8430 nM
Compound 3: middle estimate off by 1.1-fold (0.05 log units), on the high side; the range from low to high includes it.
By their numbers in this assay, from the lowest: compounds 3, 2 and 1 (each within the scatter of the next).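

At this place, on a saturated chain carbon bound to a sulfur, the earlier pair varied only the pattern of fluorine, whereas compound 3 changes both the halogen and the number of halogens on the phenyl ring. Even so, in this assay the change gives only a small step (a 1.1-fold lower number from compound 2 to compound 3 (0.06 log units; within the scatter)) and, against the other difluorophenyl group, another small step (a 1.2-fold lower number from compound 1 to compound 3 (0.08 log units; within the scatter)), and both lie within the scatter. The three halogenated phenyl groups therefore cannot be told apart in this assay, and nothing available explains why these changes leave the number within the scatter.

All three compounds still carry a phenyl ring with halogen on it at this place, so these data cannot show whether the halogen matters at all, or whether a plain phenyl, a methoxyphenyl or a phenyl ring bearing a carboxylic acid would give a similar number. They also leave open what a longer chain between the sulfur and the ring, or an amine in place of the ring, would do, and whether any change here can move the number beyond the scatter.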